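Methoxy Added to the Six-Membered Ring Analogue

The source may hold more compounds than are shown below. What is called first, only, known or untested is meant among the compounds shown, and "the series" means these compounds.

The series shares one core, varied at two places. Compound 1 `O=C1C2CCCN2C(=O)N1CN1CCN(c2ccccc2)CC1` carries a five-membered saturated ring on the core and an unsubstituted phenyl; in an assay on isolated protein for binding affinity to Adrenergic receptor alpha-1 (Rattus norvegicus), read by radioligand binding (a higher number here means a weaker inhibitor, a lower number a stronger inhibitor), compound 1 gives 1000 nM. Compound 2 `COc1ccccc1N1CCN(CN2C(=O)C3CCCN3C2=O)CC1` adds a methoxy to that phenyl, and in this assay compound 2 gives 500 nM. The step of a 2.0-fold lower number from compound 1 to compound 2 (0.30 log units; within the scatter) is therefore a small one, not beyond the scatter. Compound 3 `O=C1C2CCCCN2C(=O)N1CN1CCN(c2ccccc2)CC1` keeps the unsubstituted phenyl but enlarges the saturated ring by one carbon. In this assay compound 3 gives only a limit, > 1000 nM, so its true value is not known; it is the one case at the limit of > 1000 nM in this assay, at which 1 of the 3 values shown sits.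

Compound 4 `COc1ccccc1N1CCN(CN2C(=O)C3CCCCN3C2=O)CC1` takes the enlarged ring of compound 3 and adds the methoxy of compound 2. The change from compound 3 to compound 4 is methoxy in place of hydrogen on an aromatic carbon. Within the data shown here, the only measured step of the same kind, a 2.0-fold lower number from compound 1 to compound 2 (0.30 log units; within the scatter), lay within the scatter. In this assay compound 4 is therefore expected to show no step beyond the scatter, the estimated step from compound 3 being a step that the limit leaves unreadable from compound 3 to compound 4. Since compound 3 is known only as a limit, the estimate for compound 4 is accordingly broad: in this assay compound 4 is expected to give about 1500 nM, within a range from 500 nM to 6000 nM.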

Compound 4, inhibition constant: > 1000 nM
Compound 4 ended at the assay's limit (the forecaster's own chance of this, stated with the estimate: 55%); the middle value is on the limit's open side.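

In this assay compound 4 gives > 1000 nM, a limit of the assay and not a number. Compound 3 is also known only as a limit, so no step can be read between compound 3 and compound 4: the limit of > 1000 nM in this assay, at which 2 of the 4 values shown sit.

The compounds shown leave open where the true values of compound 3 and compound 4 lie, and whether the methoxy makes any difference on the enlarged ring.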